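Does a longer chain lower growth inhibition further?

A few compounds are considered here, and "the series" means these few. Any claim that something is new, unique, unknown or untested is made for them only; others in the source may bear on it.

compound 1 `C=C[C@@](C)(/C=C/c1ccc(OC(=O)CC)cc1)CCC=C(C)C`: 60%
compound 2 `C=C[C@@](C)(/C=C/c1ccc(OC(=O)CCC)cc1)CCC=C(C)C`: 54%
compound 3 `C=C[C@@](C)(/C=C/c1ccc(OC(=O)CCCC)cc1)CCC=C(C)C`: 15%

In a functional assay on THP-1 cells (Homo sapiens) for inhibition, with a stated time of 48 h, tested at 50 uM (on this read-out higher numbers stand for more inhibition of growth at the one concentration tested and lower numbers for less inhibition of growth), compound 3 gives 15% and is the lowest of the three. The change leading to compound 4 `C=C[C@@](C)(/C=C/c1ccc(OC(=O)CCCCC)cc1)CCC=C(C)C` is small: methyl in place of hydrogen on a saturated chain carbon, four bonds along the chain from a carbonyl carbon on the same chain. Two earlier lengthenings of this chain bear on it, and they differ in size. The first gave a number 6 percentage points lower from compound 1 to compound 2 (within the scatter) and the second gave a number 39 percentage points lower from compound 2 to compound 3 (beyond the scatter) for a total of a number 45 percentage points lower from compound 1 to compound 3 (beyond the scatter) over both. So the chain does not lower the number evenly. Compound 3 at 15% already sits low, which leaves little room for another large fall, so a small fall or none beyond the scatter is expected. In this assay the expected step is a number 3 percentage points lower from compound 3 to compound 4 (within the scatter) and no larger. Compound 4 is estimated at 12% within an expected range of 0% to 32% on this measure.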

Compound 4, percent growth inhibition at one concentration: 54%
Compound 4: the middle estimate sits 42 percentage points below what was measured; measured number above the stated range.
By their numbers in this assay, from the lowest: compound 3; then compounds 2, 4 and 1 (each within the scatter of the next).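

In this assay, the methyl added four bonds along the chain from the carbonyl carbon reverses the earlier fall, giving a number 39 percentage points higher from compound 3 to compound 4 (beyond the scatter). Compound 3 is therefore a lone low point rather than part of a steady decline with chain length, since the longer chain gives no change at the digits printed from compound 2 to compound 4 (within the scatter) and a number 6 percentage points lower from compound 1 to compound 4 (within the scatter). The effect of adding one methyl depends on where the chain already ends: the same change on two cores in this assay, a number 6 percentage points lower (within the scatter) from compound 1 to compound 2 and a number 39 percentage points higher (beyond the scatter) from compound 3 to compound 4, 45 percentage points apart, beyond the scatter of two such steps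

The compounds shown leave open whether a longer chain would hold this level or fall again. They also leave open how an amine at the chain end would read.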